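Alkyne terminus: cyclopentyl against cyclohexenyl in the series

The source may hold more compounds than are shown below. What is called first, only, known or untested is meant among the compounds shown, and "the series" means these compounds.

Measured so far:
compound 1 `O=C(O)CCc1ccc(C#CC2CCCC2)cc1` — 490 nM
compound 2 `C/C=C(\C)C#Cc1ccc(CCC(=O)O)c(F)c1` — 37.2 nM

In a functional assay on 1321-N1 cells for agonist activity at Free fatty acid receptor 1 (Homo sapiens), read by calcium flux, with a stated time of 0.4 s (on this read-out lower numbers stand for an effect already at smaller amounts and higher numbers for an effect only at larger amounts of compound), compound 1 gives 490 nM, the highest of the two numbers shown. For the measured compounds named here, compound 2 gives 37.2 nM in this assay, a gap beyond the scatter, but compound 2 differs from compound 1 in more than one place, so the two values show only that the pair sits far apart, not what any single change does.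

Compound 3 `O=C(O)CCc1ccc(C#CC2=CCCCC2)cc1` is not yet measured. It differs from compound 1 by cyclohex-1-en-1-yl in place of cyclopentyl on a triple-bonded carbon. Going by the values given here, no step between measured compounds isolates this change, so there is nothing to lean on beyond the two values above. A modest move toward a lower number is expected, not clearly beyond the scatter, giving a step of a 2.0-fold lower number from compound 1 to compound 3 (0.29 log units; within the scatter). For compound 3 in this assay the estimate is 250 nM, with a range from 80 nM to 700 nM.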

Compound 3, half-maximal effective concentration: 200 nM
Beside the measured number, compound 3's estimate is 1.3-fold (0.10 log units) above it, and the stated range covers the measured number.
By their numbers in this assay, from the lowest: compound 2; then compound 3; then compound 1.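

In this assay, for the compounds shown here, cyclohex-1-en-1-yl in place of cyclopentyl on a triple-bonded carbon gives a lower number (a 2.5-fold lower number from compound 1 to compound 3 (0.39 log units; beyond the scatter)), the first change at this position that can be read on its own, as the only earlier pair differs in more than one place. The step is modest, and it shows that this carbon accepts a larger ring carrying a double bond without loss in this read-out, although ring size and the double bond enter together and cannot be separated here. Nothing on hand accounts for the step.

Open, from the compounds shown here alone, is whether cyclohexyl or cyclopent-1-en-1-yl on the same carbon would separate ring size from the double bond. The shares of the fluorine and the open-chain alkenyl terminus in the low number of compound 2 also remain unresolved.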